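A few compounds are considered here, and "the series" means these few. Any claim that something is new, unique, unknown or untested is made for them only; others in the source may bear on it.

Working notes on the series, following the step to compound 4.

Compound 1 (`NC(=O)c1cc(Br)ccc1NC(=O)/C=C/c1ccc(Cl)cc1`) gives > 10000 nM in a functional assay on K562 cells (Homo sapiens) for inhibition, read by trypan blue exclusion, with a stated time of 48 h (a higher number here means a weaker inhibitor, a lower number a stronger inhibitor), as a limit, not a number. Compound 2 (`NC(=O)c1cc(Br)ccc1NC(=O)/C=C/c1cccc(Br)c1`) gives > 10000 nM in this assay, again only a limit. Going by these compounds, compound 3 (`Cc1ccc(/C=C/C(=O)Nc2ccc(Br)cc2C(N)=O)cc1`) gives > 10000 nM in this assay, also only a limit, so its true position is unknown. The whole set stands as the limit of > 10000 nM in this assay, at which 3 of the 3 values shown sit, and no number is available yet.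

For the measured compounds named here, compound 4 (`Cc1ccc(/C=C/C(=O)Nc2ccc(I)cc2C(N)=O)cc1`) keeps the 4-methylphenyl group of compound 3 and carries iodo in place of bromo on an aromatic carbon, para to a large group (iodo in place of bromo on an aromatic carbon) as its only change.

The measured steps give little guidance. They are a step that the two limits leave unreadable from compound 1 to compound 2 and a step that the two limits leave unreadable from compound 1 to compound 3 and a step that the two limits leave unreadable from compound 2 to compound 3 and no size can be read from any of them. Each alters the aromatic group on the double-bonded chain, and none touches the bromo.

No size or direction can therefore be carried over, and the working assumption is a result close to the limit, with a wide range. The step expected is an at least 1.6-fold lower number from compound 3 to compound 4 (0.22 log units; that floor lies within the scatter) in this assay and it is only loosely estimated. For compound 4 the expected value is 6000 nM with an estimated range from 600 nM to 20000 nM in this series.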

Compound 4, half-maximal inhibitory concentration: > 10000 nM
Compound 4 gave a limit, no number (the forecaster's own chance of this, stated with the estimate: 55%); middle value at least 1.6-fold (0.22 log units) away from the limit.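

Compound 3 and compound 4 both stand only as limits, so no step can be read between them, and iodo in place of bromo has no readable size. The compounds shown leave open where any of them truly lies and which change, if any, would give a number in this assay, where the series stands at one limit: the limit of > 10000 nM in this assay, at which 4 of the 4 values shown sit.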